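Dropping the methoxy from compound 2: what the parent should give

The compounds below may be only part of what the source reports. "The series", "measured", "known", "first", "only" and "open" are said of these compounds alone.

Two members of this series carry a value in a functional assay on MDA-MB-231 cells (Homo sapiens) for inhibition, read by MTT assay, with a stated time of 48 h; on this read-out lower numbers stand for stronger inhibition and higher numbers for weaker inhibition. Compound 1, with structure `Cc1[nH]c2ccccc2c1C1CC(c2ccncc2)=NO1`, gives 26600 nM in this assay. Compound 2, with structure `COc1ccc2c(C3CC(c4ccncc4)=NO3)c[nH]c2c1`, gives 7380 nM in this assay and so holds the lower of the two numbers, with compound 1 standing at a higher number by a gap that lies beyond the usual scatter. Going by the values given here, the two compounds differ in more than one place, so no single step between them can be read off.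

Compound 3, with structure `c1ccc2c(C3CC(c4ccncc4)=NO3)c[nH]c2c1`, has not yet been measured. It differs from compound 2 in one place: hydrogen in place of methoxy on an aromatic carbon.

Among the compounds with values here, no measured pair in this set isolates the loss of a methoxy group, so the size of the step can only be guessed. Within the data shown here, the expectation for this assay is a modest move toward a higher number, possibly still within the scatter, since the only other compound without that group, compound 1, sits at 26600 nM. On that basis compound 3 is expected to give 12000 nM in this assay, within a range from 4000 nM to 35000 nM. This estimate corresponds to an expected step of a 1.6-fold higher number from compound 2 to compound 3 (0.21 log units; within the scatter).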

Compound 3, half-maximal inhibitory concentration: 19700 nM
Estimate against measurement, compound 3: 1.6-fold (0.22 log units) below; measured number inside the range.
By their numbers in this assay, from the lowest: compound 2; then compounds 3 and 1 (each within the scatter of the next).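

In this assay, going by these compounds alone, hydrogen in place of methoxy on the aromatic carbon that is meta to a fused ring and para to a fused ring gives a 2.7-fold higher number from compound 2 to compound 3 (0.43 log units; beyond the scatter) and so provides the first single-change reading in this set: a modest step, but one beyond the scatter, which ties the lower number of compound 2 to its methoxy group. Hydrogen in place of methyl on an aromatic carbon, at a different place on the core, gives a 1.4-fold lower number from compound 1 to compound 3 (0.13 log units; within the scatter) and leaves compound 1 and compound 3 within the scatter of each other, so that change shows no measurable effect on this read-out. Nothing given here accounts for either step.

From the compounds shown here alone, what remains open is whether the step belongs to methoxy itself or would also appear with another group on the same carbon, such as a hydroxyl, a fluorine or an amine. Going by these compounds, it is also open whether a longer chain such as ethoxy would move the number further in this assay or lose the step altogether.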